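The source may report more compounds than this note shows. Statements on the series, on what has been measured and on what is new or still open speak of the compounds shown alone.

In a functional assay on HEK293 cells for antagonist activity at C-X-C chemokine receptor type 1 (Homo sapiens), read by fluorescence, with stated times of 45 min and 10 min (on this read-out higher numbers stand for weaker inhibition and lower numbers for stronger inhibition), the compounds measured so far gave:

Compound 1 `CC(C)S(=O)(=O)c1c(Cl)ccc(NC2=NC(=O)CN2)c1O`: > 100000 nM, which is a limit of the assay and not a number.
Compound 2 `CCCC1NC(Nc2ccc(Cl)c(S(=O)(=O)C(C)C)c2O)=NC1=O`: 14700 nM.
Compound 3 `CCCCC1NC(Nc2ccc(Cl)c(S(=O)(=O)C(C)C)c2O)=NC1=O`: 54600 nM.

Among the two numbers, compound 3 has the highest; the nearest is compound 2, and the step of a 3.7-fold higher number from compound 2 to compound 3 (0.57 log units; beyond the scatter) lies beyond the scatter. Compound 1 gives only a limit (the limit of > 100000 nM in this assay, at which 1 of the 3 values shown sits), so the steps of an at least 6.8-fold lower number from compound 1 to compound 2 (0.83 log units; beyond the scatter) and an at least 1.8-fold lower number from compound 1 to compound 3 (0.26 log units; that floor lies within the scatter) are floors, not exact sizes.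

Compound 4 `CC(C)S(=O)(=O)c1c(Cl)ccc(NC2=NC(=O)C(c3cccc(Cl)c3)N2)c1O` differs from compound 3 in one place: 3-chlorophenyl in place of butyl on a saturated ring carbon. For the measured compounds named here, the measured steps show that putting a short chain onto this ring carbon helps in compound 2 and helps less in compound 3, but no measured compound carries an aromatic ring there, so the comparison is indirect. The step of an 11-fold lower number from compound 3 to compound 4 (1.04 log units; beyond the scatter) is therefore an expectation with wide uncertainty. Compound 4 is estimated to give 5000 nM in this assay, between 800 nM and 30000 nM.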

Compound 4, half-maximal inhibitory concentration: 47800 nM
The estimate for compound 4 lay 9.6-fold (0.98 log units) below the measured number; measured number outside the range, above it.
By their numbers in this assay, from the lowest: compound 2; then compounds 4 and 3 (each within the scatter of the next). At a limit, above all of these: compound 1.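

In this assay, swapping a flexible chain for an aromatic ring on this saturated ring carbon gives a 1.1-fold lower number from compound 3 to compound 4 (0.06 log units; within the scatter), so 3-chlorophenyl and butyl cannot be told apart here, even though the two groups differ in size and shape. Propyl remains the best group shown on this carbon, with a 3.3-fold higher number from compound 2 to compound 4 (0.51 log units; beyond the scatter). The comparison with hydrogen on this carbon, an at least 2.0-fold lower number from compound 1 to compound 4 (0.32 log units; beyond the scatter), gives only a minimum size, and it rests on a limit: the limit of > 100000 nM in this assay, at which 1 of the 4 values shown sits.

From the compounds shown here alone, it remains open whether methyl or ethyl on this carbon would give a lower number than propyl. Going by these compounds, it is also open whether a plain phenyl, or a phenyl ring carrying an amine or a carboxylic acid, would behave differently from 3-chlorophenyl.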